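The source may report more compounds than this note shows. Statements on the series, on what has been measured and on what is new or still open speak of the compounds shown alone.

Values in a physicochemical assay for solubility, at pH 6.8; a lower number here means a less soluble compound, a higher number a more soluble compound:
- Compound 1 `Cc1c(COc2cccc(OCC3CCOCC3)c2)[nH]c2ccc(C(=O)O)cc2c1=O`: >= 100000 nM, a limit and not a number.
- Compound 2 `COc1ccc2[nH]c(COc3cccc(OCC4CCOCC4)c3)c(C)c(=O)c2c1`: < 1000 nM, a limit and not a number.
- Compound 3 `Cc1c(COc2cccc(OCC3CCOCC3)c2)[nH]c2ccccc2c1=O`: 5000 nM.

Only compound 3 has an exact number, so it is the natural starting point. Compound 4 `Cc1c(COc2cccc(OCC3CCOCC3)c2)[nH]c2ccc(-c3cccnc3)cc2c1=O` differs from it by one change: pyridin-3-yl in place of hydrogen on an aromatic carbon.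

The measured steps all concern this same carbon. The large step of an at least 20-fold lower number from compound 1 to compound 3 (1.30 log units; beyond the scatter) removes a carboxy group, but the incoming pyridin-3-yl has no net charge, so that step is a weak guide. The closer comparison is with the methoxy group of compound 2, which gives an at least 5.0-fold higher number from compound 2 to compound 3 (0.69 log units; beyond the scatter). Read in reverse, this shows a lower number when hydrogen gives way to methoxy, so a similar direction seems likely here, though pyridin-3-yl is a much larger group and has not been tested.

The expected change is a 3.3-fold lower number from compound 3 to compound 4 (0.52 log units; beyond the scatter), a modest fall. For compound 4 the estimate is 1500 nM, with an expected range of 400 nM to 6000 nM.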

Compound 4, solubility: < 1000 nM
Compound 4 gave a limit, no number; the forecaster's own chance of this, stated with the estimate: 45%; middle value at least 1.5-fold (0.17 log units) away from the limit.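

Until now this aromatic carbon had carried only hydrogen, methoxy or carboxy, and compound 4 extends the picture to a whole aromatic ring: in this assay, pyridin-3-yl gives an at least 5.0-fold lower number from compound 3 to compound 4 (0.69 log units; beyond the scatter). Methoxy and pyridin-3-yl, the two groups shown replacing hydrogen without a net charge, both go with a lower number than hydrogen, and neither compound goes against this, while the distance from the carboxy compound is large: an at least 100-fold lower number from compound 1 to compound 4 (2.00 log units; beyond the scatter). The result for compound 4 is a limit and not a number: the limit of < 1000 nM in this assay, at which 2 of the 4 values shown sit.

The step from compound 2 to compound 4 cannot be read, so methoxy and pyridin-3-yl cannot be ranked against each other. From the compounds shown here alone, it also remains open whether an amine or a carboxylic acid attached to the pyridin-3-yl ring would bring the number back towards that of compound 1.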